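Swapping methyl for trifluoromethyl on an inactive aryl thiophene

A few compounds are considered here, and "the series" means these few. Any claim that something is new, unique, unknown or untested is made for them only; others in the source may bear on it.

Three acrylamides were tested in a functional assay on BGC-823 cells (Homo sapiens) for cytotoxicity, read by CCK-8 assay, with a stated time of 24 h (on this read-out lower numbers stand for stronger inhibition and higher numbers for weaker inhibition), and none of them gave a number. Compound 1, `C=C1CCC(c2csc(/C=C(\C)C(N)=O)c2)CC1`, reached only the limit of the assay, > 50000 nM. Compound 2, `C/C(=C\c1cc(-c2ccc(C)cc2)cs1)C(N)=O`, likewise stopped at the limit, > 50000 nM. Compound 3, `C/C(=C\c1nc(-c2ccccc2)cs1)C(N)=O`, sits at the same limit, > 50000 nM. Going by the values given here, compound 2 therefore stands nowhere in particular within this set; all three share (the limit of > 50000 nM in this assay, at which 3 of the 3 values shown sit), and no step between measured compounds can be drawn.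

Compound 4, `C/C(=C\c1cc(-c2ccc(C(F)(F)F)cc2)cs1)C(N)=O`, differs from compound 2 by trifluoromethyl in place of methyl on an aromatic carbon. Among the compounds with values here, with no measured step available to guide the direction, the change from compound 2 to compound 4 is expected to produce nothing beyond the scatter in this assay. The step that this expectation implies, a step that the limit leaves unreadable from compound 2 to compound 4, is estimated to be negligible. Compound 4 is accordingly expected to give about 60000 nM, somewhere between 20000 nM and 200000 nM, most likely again as a limit rather than a number.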

Compound 4, half-maximal inhibitory concentration: > 50000 nM
Compound 4 gave a limit, no number (the forecaster's own chance of this, stated with the estimate: 80%); the middle value lies beyond the limit too.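

Compound 2 and compound 4 both end at a limit in this assay, so no step can be read between them: the limit of > 50000 nM in this assay, at which 4 of the 4 values shown sit.

The compounds shown leave open whether trifluoromethyl in place of methyl on an aromatic carbon alters cytotoxicity at all, and what would give a measurable number.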